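This account rests on a few compounds, and the source may have more. Where it says the series, first, only, none or still open, it means among the compounds named here.

Measured so far:
Compound 1, `O=C(O)c1c(O)cccc1CCc1ccc2ccccc2c1`, in an ADME assay on HepG2 cells (Homo sapiens) for cytotoxicity, read by resazurin assay, with a stated time of 24 h; a lower number here means that less compound is tolerated, a higher number that more compound is tolerated: > 100000 nM
Compound 2, `Cc1cc(O)c(C(=O)O)c(CCc2ccc3ccccc3c2)c1`: 38000 nM
Compound 3, `COc1cccc(C=Cc2ccc3ccccc3c2)c1C(=O)O`: > 100000 nM

The value of compound 1 in this assay is a limit of the assay, not a number. The value of compound 3 in this assay is likewise a limit. Compound 2, in contrast, gives a number, 38000 nM, so the step of an at least 2.6-fold lower number from compound 1 to compound 2 (0.42 log units; beyond the scatter) is known only as a lower bound, because of the limit of > 100000 nM in this assay, at which 2 of the 3 values shown sit. The change behind that step is methyl in place of hydrogen on an aromatic carbon.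

Compound 4, `COc1cc(C)cc(C=Cc2ccc3ccccc3c2)c1C(=O)O`, has not yet been measured in this assay. It differs from compound 3 by methyl in place of hydrogen on an aromatic carbon. Among the compounds with values here, this is the same kind of change as the one from compound 1 to compound 2, though not the same: in compound 2 the methyl sits meta to a hydroxy group (1 heavy atom), whereas in compound 4 it sits meta to a methoxy group (2 heavy atoms). How the core of compound 1 differs from the core of compound 3 is not broken down here.

Resting on the single measured step of an at least 2.6-fold lower number from compound 1 to compound 2 (0.42 log units; beyond the scatter), compound 4 is expected to tolerate somewhat less than compound 3, an estimated step of an at least 1.6-fold lower number from compound 3 to compound 4 (0.22 log units; that floor lies within the scatter). Compound 4 is therefore estimated at 60000 nM in this assay, expected to lie between 25000 nM and 150000 nM, with a real chance that the assay again reports only a limit.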

Compound 4, half-maximal cytotoxic concentration: 117000 nM
For compound 4 the middle estimate is 2.0-fold (0.29 log units) below the measured one; measured number inside the range.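

The step from compound 3 to compound 4 cannot be read in this assay, because the value of compound 3 is a limit of the assay and not a number: the limit of > 100000 nM in this assay, at which 2 of the 4 values shown sit. The compounds shown leave open whether methyl in place of hydrogen on an aromatic carbon changes the number between compound 3 and compound 4 at all, and so whether it matches the step between compound 1 and compound 2.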